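The source may hold more compounds than are shown below. What is called first, only, known or untested is meant among the compounds shown, and "the series" means these compounds.

Measured so far in a functional assay on KYSE-450 cells (Homo sapiens) for inhibition, read by CCK-8 assay, with a stated time of 48 h (on this read-out higher numbers stand for weaker inhibition and lower numbers for stronger inhibition), to date:
- compound 1 `COc1ccc(CN(C(=O)CSC(=S)N2CCN(C)CC2)c2cc(OC)c(OC)c(OC)c2)cc1` gives 1250 nM
- compound 2 `COc1ccc(CN(C(=O)CSC(=S)N2CCCc3cc(C)ccc32)c2cc(OC)c(OC)c(OC)c2)cc1` gives 5210 nM

Compound 2 holds the higher of the two numbers (5210 nM) and is therefore the weaker inhibitor of this pair. Next comes compound 3 `COc1ccc(CN(C(=O)CSC(=S)N2CCCc3cc(OC)ccc32)c2cc(OC)c(OC)c(OC)c2)cc1`, which differs from compound 2 by methoxy in place of methyl on an aromatic carbon in one place: methoxy in place of methyl on an aromatic carbon, turning 6-methyl-1,2,3,4-tetrahydroquinolin-1-yl into 6-methoxy-1,2,3,4-tetrahydroquinolin-1-yl.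

Among the compounds with values here, only one measured step bears on this: a 4.2-fold higher number from compound 1 to compound 2 (0.62 log units; beyond the scatter). That step replaced the whole group on the thiocarbonyl carbon, whereas the present change is far smaller and lies within that group. Within the data shown here, no measured pair shows methyl against methoxy, so the data give no direction. A step clearly smaller than the one measured is expected, most likely within the scatter in this assay. The estimated change is a 1.2-fold lower number from compound 2 to compound 3 (0.08 log units; within the scatter) and the direction is only a weak guess. For compound 3 the estimated value is 4300 nM (expected range 1900 nM to 9500 nM).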

Compound 3, half-maximal inhibitory concentration: 5530 nM
The estimate for compound 3 lay 1.3-fold (0.11 log units) below the measured number, and the stated range covers the measured number.
By their numbers in this assay, from the lowest: compound 1; then compounds 2 and 3 (each within the scatter of the next).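

In this assay, within the data shown here, methoxy in place of methyl on this aromatic carbon gives a 1.1-fold higher number from compound 2 to compound 3 (0.03 log units; within the scatter) and so leaves the two compounds indistinguishable, the first reading of this position. The distance from the 4-methylpiperazin-1-yl group also holds with the second tetrahydroquinoline, with a 4.4-fold higher number from compound 1 to compound 3 (0.65 log units; beyond the scatter) alongside the earlier step to compound 2, so both 6-substituted 1,2,3,4-tetrahydroquinolin-1-yl compounds give higher numbers than compound 1 and neither goes against that reading. No outside evidence accompanies these numbers, and the steps stand here as bare observations without any explanation.

Going by these compounds, it remains open whether this position stays as flat with groups other than methyl and methoxy, such as a chlorine atom, a carboxylic acid or a dimethylamino group, since two close values on one aromatic carbon say little about the wider range of substituents there. On these data alone, on the thiocarbonyl carbon, it also remains open how piperidin-1-yl, morpholin-4-yl or an open-chain diethylamino group would compare with 4-methylpiperazin-1-yl.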